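Hydroxy in place of chloro on the shared core

The source may report more compounds than this note shows. Statements on the series, on what has been measured and on what is new or still open speak of the compounds shown alone.

Values in an ADME assay on L132 cells (Homo sapiens) for cytotoxicity, read by MTT assay, with a stated time of 72 h; on this read-out higher numbers stand for weaker inhibition and lower numbers for stronger inhibition:
- Compound 1 `COc1ccc(C2=C(c3cc(OC)c(OC)c(OC)c3)C(=O)C(OC(C)=O)C2)cc1OC(C)C`: > 100 ug/mL, a limit
- Compound 2 `COc1ccc(C2=C(c3cc(OC)c(OC)c(OC)c3)C(=O)C(OC(C)=O)C2)cc1F`: < 1 ug/mL, a limit
- Compound 3 `COc1ccc(C2=C(c3cc(OC)c(OC)c(OC)c3)C(=O)C(OC(C)=O)C2)cc1Cl`: < 1 ug/mL, a limit

In this assay compound 3 gives < 1 ug/mL, which is a limit and not a number. It sits at the limit of < 1 ug/mL in this assay, at which 2 of the 3 values shown sit, and the comparison with compound 2 gives a step that the two limits leave unreadable from compound 2 to compound 3.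

The open case is compound 4 `COc1ccc(C2=C(c3cc(OC)c(OC)c(OC)c3)C(=O)C(OC(C)=O)C2)cc1O`. The change is hydroxy in place of chloro on an aromatic carbon, ortho to a methoxy group.

Among the measured compounds shown here, two measured steps bear on this place, and both are large: an at least 100-fold lower number from compound 1 to compound 2 (2.00 log units; beyond the scatter) and an at least 100-fold lower number from compound 1 to compound 3 (2.00 log units; beyond the scatter). They show that the group on this carbon can matter, but neither measures hydroxy. For the measured compounds named here, compound 1 is the only measured compound with oxygen on this carbon, as compound 4 has, so a shift towards higher numbers remains possible. Even so, no step beyond the scatter is the expectation, though the limit on compound 3 leaves its size open.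

For compound 4 the expected value is 0.5 ug/mL, with an estimated range of 0.05 ug/mL to 8 ug/mL.

The estimate corresponds to an expected step that the limit leaves unreadable from compound 3 to compound 4.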

Compound 4, half-maximal inhibitory concentration: 6 ug/mL
Beside the measured number, compound 4's estimate is 12-fold (1.08 log units) below it, within the range that was stated.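

In this assay hydroxy on this aromatic carbon does not behave like either halogen: an at least 6.0-fold higher number from compound 3 to compound 4 (0.77 log units; beyond the scatter), and an at least 6.0-fold higher number from compound 2 to compound 4 (0.77 log units; beyond the scatter). It does not behave like isopropoxy either, with an at least 16-fold lower number from compound 1 to compound 4 (1.22 log units; beyond the scatter), so having oxygen on this carbon does not by itself fix the read-out, and the group carried on that oxygen also counts. Among the compounds shown here, compound 4, at 6 ug/mL, gives the first true number at this position. Compound 3 remains a limit: the limit of < 1 ug/mL in this assay, at which 2 of the 4 values shown sit.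

Going by these compounds, compound 1 is also a limit, so the full size of the step from compound 1 to compound 4 stays open: the limit of > 100 ug/mL in this assay, at which 1 of the 4 values shown sits. Also open is whether an amine or a carboxylic acid on this carbon, or an ethoxy group or a longer chain on the oxygen, would sit with hydroxy, with the halogens or with isopropoxy, and the step between fluoro and chloro cannot be read.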